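Swapping trifluoromethyl for fluoro: an untested position

The compounds below may be only part of what the source reports. "The series", "measured", "known", "first", "only" and "open" are said of these compounds alone.

Of the compounds shown here, three of a shared core have been measured in an ADME assay on HEK-293T cells (Homo sapiens) for cytotoxicity, read by MTT assay, with a stated time of 24 h; a lower number here means that less compound is tolerated, a higher number that more compound is tolerated. Compound 1 `Cc1ccc(C(=O)n2c(-c3cn(-c4ccccc4)nc3-c3ccc(C(F)(F)F)cc3)nc3ccccc32)cc1` gives 169000 nM in this assay. Compound 2 `O=C(c1ccc(Cl)cc1)n1c(-c2cn(-c3ccccc3)nc2-c2ccc(C(F)(F)F)cc2)nc2ccccc21` gives 181000 nM, and compound 3 `Cc1ccc(C(=O)n2c(-c3cn(-c4ccccc4)nc3-c3ccc(C(F)(F)F)cc3)nc3ccccc32)cn1` gives 153000 nM. Compound 2 holds the highest of the three numbers, yet its gaps to the others are small: a 1.1-fold higher number from compound 1 to compound 2 (0.03 log units; within the scatter) and a 1.2-fold lower number from compound 2 to compound 3 (0.07 log units; within the scatter), both within the scatter, as is a 1.1-fold lower number from compound 1 to compound 3 (0.04 log units; within the scatter). The three compounds are, in effect, indistinguishable in this assay.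

Compound 4 `O=C(c1ccc(Cl)cc1)n1c(-c2cn(-c3ccccc3)nc2-c2ccc(F)cc2)nc2ccccc21` is not yet measured. It differs from compound 2 in one place: fluoro in place of trifluoromethyl on an aromatic carbon. Among the compounds with values here, none of the measured steps touches this position; all three exchange the group on the carbonyl carbon, and each stayed within the scatter. Nothing here points to a change beyond the scatter for compound 4. The step from compound 2 to compound 4 is therefore expected to be a 1.0-fold lower number from compound 2 to compound 4 (0.01 log units; within the scatter). Compound 4 is estimated to give 175000 nM in this assay, within a range of 85000 nM to 360000 nM.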

Compound 4, half-maximal cytotoxic concentration: 179000 nM
Beside the measured number, compound 4's estimate is 1.0-fold (0.01 log units) below it; the range from low to high includes it.
By their numbers in this assay, from the lowest: compounds 3, 1, 4 and 2 (each within the scatter of the next).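

Within the data shown here, this is the first step at the aromatic carbon of the 4-(trifluoromethyl)phenyl group, as all the earlier steps exchanged the group on the carbonyl carbon. In this assay, fluoro in place of trifluoromethyl gives a 1.0-fold lower number from compound 2 to compound 4 (0.00 log units; within the scatter), so compound 2 and compound 4 cannot be told apart, and this position, for these two groups, behaves like the carbonyl side, with no step beyond the scatter. No supporting measurement is available that could account for this result.

As far as these compounds go, whether an amine, a carboxylic acid or a longer carbon chain on this same aromatic carbon would also stay within the scatter remains open. From the compounds shown here alone, it is also open whether fluoro here would give the same picture with 4-methylphenyl or 6-methylpyridin-3-yl on the carbonyl carbon.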